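Swapping a fluorophenyl for thiophene on the weakest pyrazoline

A few compounds are considered here, and "the series" means these few. Any claim that something is new, unique, unknown or untested is made for them only; others in the source may bear on it.

Measured compounds:
compound 1 `Cc1ccc(C2=NN(C(N)=S)C(c3ccc(Cl)cc3)C2)cc1`: 15 nM
compound 2 `NC(=S)N1N=C(c2ccc(F)cc2)CC1c1ccc(Cl)cc1`: 1000 nM
compound 3 `Cc1ccc(C2CC(c3ccc(F)cc3)=NN2C(N)=S)cc1`: 50 nM

In an assay on mitochondria for inhibition of Amine oxidase [flavin-containing] B (Bos taurus) (on this read-out lower numbers stand for stronger inhibition and higher numbers for weaker inhibition), compound 2 gives the highest number of the three, so it is the weakest inhibitor shown. Compound 4 `NC(=S)N1N=C(c2cccs2)CC1c1ccc(Cl)cc1` arises from compound 2 by thiophen-2-yl in place of 4-fluorophenyl on a carbon with a double bond to nitrogen. The step that bears most directly on this change is a 67-fold higher number from compound 1 to compound 2 (1.82 log units; beyond the scatter), which altered the same aryl group and made binding much weaker; the other step, a 20-fold lower number from compound 2 to compound 3 (1.30 log units; beyond the scatter), changed the group on the other ring carbon. Going by the values given here, since replacing the 4-fluorophenyl removes the fluoro-bearing ring that accompanied weak binding, a lower number is expected for compound 4, though the new group has no precedent here, so the estimate a 6.7-fold lower number from compound 2 to compound 4 (0.82 log units; beyond the scatter) is moderate and uncertain. Compound 4 is expected to give 150 nM in this assay, within 30 nM to 800 nM.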

Compound 4, inhibition constant: 6 nM
Compound 4: middle estimate off by 25-fold (1.40 log units), on the high side; measured number outside the range, below it.
By their numbers in this assay, from the lowest: compound 4; then compound 1; then compound 3; then compound 2.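

At this position, on a carbon with a double bond to nitrogen, thiophen-2-yl in place of 4-fluorophenyl gives the largest step in the series (a 170-fold lower number from compound 2 to compound 4 (2.22 log units; beyond the scatter)), so the shared core can bind strongly and the weak binding of compound 2 goes with its 4-fluorophenyl group. Thiophen-2-yl also improves on 4-methylphenyl (a 2.5-fold lower number from compound 1 to compound 4 (0.40 log units; beyond the scatter)), so a six-membered aromatic ring is not required here. No measurement explains why either change strengthens binding. Still open, going by these compounds, is whether a furan-2-yl ring or an amine at this position would keep binding this strong.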